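This account rests on a few compounds, and the source may have more. Where it says the series, first, only, none or still open, it means among the compounds named here.

Going by the values given here, compound 3 `COc1cccc(S(=O)(=O)c2ccccc2Cc2c3c(n(CC(=O)O)c2C)CCNC3=O)c1` is one of three compounds measured in a functional assay on CHO.K1 cells for antagonist activity at prostaglandin D2 receptor 2 (Homo sapiens), read by GTPgammaS binding, with a stated time of 1 h; on this read-out higher numbers stand for weaker inhibition and lower numbers for stronger inhibition. There compound 3 gives 12 nM, the second highest of the three numbers. Compound 1 `CNC(=O)c1ccc(Cc2c3c(n(CC(=O)O)c2C)CCNC3=O)c(S(=O)(=O)c2ccccc2)c1` gives 10 nM, within the scatter of compound 3. Compound 2 `COc1cccc(S(=O)(=O)c2ccccc2)c1Cc1c2c(n(CC(=O)O)c1C)CCNC2=O` gives 4500 nM, far beyond the scatter above compound 3.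

Compound 4 `Cc1c(Cc2ccccc2C(O)c2ccccc2)c2c(n1CC(=O)O)CCNC2=O` has not yet been measured in this assay. It differs from compound 3 in one place: hydroxy(phenyl)methyl in place of (3-methoxyphenyl)sulfonyl on an aromatic carbon. Among the compounds with values here, no measured pair shows this change, so the expectation rests on compound 3 alone. A modest step toward weaker inhibition is expected, a 5.0-fold higher number from compound 3 to compound 4 (0.70 log units; beyond the scatter), but it could also be none beyond the scatter. Compound 4 is expected to give about 60 nM, within 15 nM to 300 nM.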

Compound 4, half-maximal inhibitory concentration: 32 nM
Estimate against measurement, compound 4: 1.9-fold (0.27 log units) above; the range from low to high includes it.
By their numbers in this assay, from the lowest: compounds 1 and 3 (each within the scatter of the next); then compound 4; then compound 2.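

In this assay, hydroxy(phenyl)methyl can stand in for (3-methoxyphenyl)sulfonyl on this aromatic carbon at a modest cost, a 2.7-fold higher number from compound 3 to compound 4 (0.43 log units; beyond the scatter), even though the sulfonyl is gone. A sulfonyl group is therefore not required at this place, since compound 4 still gives 32 nM without one. As far as these compounds go, whether the hydroxyl of the new group matters stays open, as does how a plain benzyl group or an amine would fare on this carbon. Nothing measured here explains the size of this step.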